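This account rests on a few compounds, and the source may have more. Where it says the series, first, only, none or still open, it means among the compounds named here.

In an ADME assay on Huh-7 cells (Homo sapiens) for cytotoxicity (on this read-out lower numbers stand for higher toxicity in this test and higher numbers for lower toxicity in this test), compound 1 `O=c1cc(CNCc2ccccc2[N+](=O)[O-])oc2ccc(O)c(O)c12` gives 41300 nM. Compound 2 `Cc1ccccc1CNCc1cc(=O)c2c(O)c(O)ccc2o1` gives 52200 nM. For compound 3 `O=c1cc(CNCc2cccc([N+](=O)[O-])c2)oc2ccc(O)c(O)c12` this assay gives only a limit, > 100000 nM.

The measured step of a 1.3-fold higher number from compound 1 to compound 2 (0.10 log units; within the scatter) is the change (methyl in place of nitro on an aromatic carbon). Compound 4 `Cc1cccc(CNCc2cc(=O)c3c(O)c(O)ccc3o2)c1` has not been measured; it differs from compound 3 by methyl in place of nitro on an aromatic carbon. This is the same kind of change, but the methyl enters meta to a large group rather than ortho to a large group. How the cores of compound 1 and compound 3 differ is not broken down here. Since compound 3 sits at the limit of > 100000 nM in this assay, at which 1 of the 3 values shown sits, its starting point is itself uncertain. The step from compound 3 to compound 4 is expected to be a step that the limit leaves unreadable from compound 3 to compound 4, resting on a 1.3-fold higher number from compound 1 to compound 2 (0.10 log units; within the scatter). Compound 4 is therefore estimated at 120000 nM, between 50000 nM and 300000 nM.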

Compound 4, half-maximal cytotoxic concentration: > 100000 nM
Compound 4: no number, only a limit (the forecaster's own chance of this, stated with the estimate: 60%); the middle value does not contradict the limit.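

In this assay compound 4 gives > 100000 nM as a limit and not as a number. Methyl in place of nitro gives a 1.3-fold higher number from compound 1 to compound 2 (0.10 log units; within the scatter) on one core, but the same change from compound 3 to compound 4 cannot be read, because both compounds stand at the same limit: the limit of > 100000 nM in this assay, at which 2 of the 4 values shown sit. Among the compounds shown here, the one readable new step, 3-methylphenyl in place of 2-methylphenyl, is an at least 1.9-fold higher number from compound 2 to compound 4 (0.28 log units; that floor lies within the scatter) and so shows no separation beyond the scatter, which leaves the carrying over of the change from one core to the other neither confirmed nor refuted.

The compounds shown leave open whether methyl and nitro would differ on the core of compound 3 at all. They also leave open what an amine or a carboxylic acid in that place would give in this assay on either core.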